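Cytotoxicity Limits for Three Compounds and an Expected Fourth

This account rests on a few compounds, and the source may have more. Where it says the series, first, only, none or still open, it means among the compounds named here.

Compound 1 `Cc1cc(C#N)cc(C)c1Oc1nc(Nc2ccc(C#N)cc2)ncc1/C=C/C(N)=O` gives > 243 nM in an ADME assay on TZM cells (Homo sapiens) for cytotoxicity, with a stated time of 1 days (on this read-out lower numbers stand for higher toxicity in this test and higher numbers for lower toxicity in this test), a limit of the assay rather than a number.
Compound 2 `Cc1cc(C#N)cc(C)c1Oc1nc(Nc2ccc(C#N)cc2)ncc1/C=C/C(=O)NC1CCN(S(=O)(=O)C(F)(F)F)CC1` gives > 160 nM in this assay, again a limit of the assay.
Compound 3 `Cc1cc(C#N)cc(C)c1Oc1nc(Nc2ccc(C#N)cc2)ncc1/C=C/C(=O)N1CCN(S(=O)(=O)C(F)(F)F)CC1` gives > 164 nM in this assay, also a limit of the assay.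

Compound 1 therefore stands nowhere in particular among these numbers: its result is a limit, and the two further results shown are limits as well, as the limit of > 243 nM in this assay, at which 1 of the 3 values shown sits, the limit of > 160 nM in this assay, at which 1 of the 3 values shown sits, and the limit of > 164 nM in this assay, at which 1 of the 3 values shown sits, state. For the measured compounds named here, none of the three compounds reached a measurable level of toxicity within the tested range, and no step between two measured compounds can be drawn.

Compound 4 `Cc1cc(C#N)cc(C)c1Oc1nc(Nc2ccc(C#N)cc2)ncc1/C=C/C(=O)NCCN1CCN(S(C)(=O)=O)CC1` differs from compound 1 in one place: 2-(4-(methylsulfonyl)piperazin-1-yl)ethyl in place of hydrogen on an amide-type nitrogen. Going by the values given here, no measured pair shows what such a change does in this assay, so the expectation rests on compound 1 alone.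

Because compound 1 gives > 243 nM, a limit, compound 4 is expected to remain untoxic in the same way. The step from compound 1 to compound 4 is estimated as a step that the limit leaves unreadable from compound 1 to compound 4, meaning no shift beyond the scatter toward higher toxicity. Compound 4 is thus expected to give 500 nM, within a range from 160 nM to 5000 nM, and most probably again only a limit.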

Compound 4, half-maximal cytotoxic concentration: > 166 nM
Compound 4 ended at the assay's limit (the forecaster's own chance of this, stated with the estimate: 75%); the middle value is on the limit's open side.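

For the compounds shown here, compound 1 and compound 4 each gave only a limit in this assay, and no step between these two compounds can be read. The compounds shown leave open the concentration at which any of them becomes toxic to these cells, and whether 2-(4-(methylsulfonyl)piperazin-1-yl)ethyl in place of hydrogen changes that concentration at all.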